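Removing the Nitrile: A Phenyl Analogue Awaiting Measurement

A few compounds are considered here, and "the series" means these few. Any claim that something is new, unique, unknown or untested is made for them only; others in the source may bear on it.

Of the compounds shown here, three with a shared core have been measured in a functional assay on C6 cells (Rattus norvegicus) for cytotoxicity, read by MTT assay, with a stated time of 24 h, tested at 25 ug/mL; on this read-out lower numbers stand for a stronger effect and higher numbers for a weaker effect at the one concentration tested. Compound 1 `Cn1cnnc1SCC(=O)N/N=c1/scc(-c2ccc(C#N)cc2)n1-c1ccccc1` gives 58.8% in this assay, compound 2 `Cn1nnnc1SCC(=O)N/N=c1/scc(-c2ccc(C#N)cc2)n1-c1ccccc1` gives 43.9%, and compound 3 `N#Cc1ccc(-c2cs/c(=N/NC(=O)CSc3nnnn3-c3ccccc3)n2-c2ccccc2)cc1` gives 64.2%. Compound 2 shows the lowest number of the three, and thus the strongest effect, since the steps of a number 14.9 percentage points lower from compound 1 to compound 2 (beyond the scatter) and a number 20.3 percentage points higher from compound 2 to compound 3 (beyond the scatter) both lie beyond the scatter; the step of a number 5.4 percentage points higher from compound 1 to compound 3 (within the scatter) lies within it.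

Compound 4 `Cn1nnnc1SCC(=O)N/N=c1/scc(-c2ccccc2)n1-c1ccccc1` is not yet measured. It differs from compound 2 in one place: hydrogen in place of cyano on an aromatic carbon. For the measured compounds named here, every measured step changes the heteroaryl group on the sulfur or the substituent on its aromatic nitrogen; no measured step touches the cyano group on the six-membered aromatic ring of carbon only. The measured steps therefore give no direct guide to the size or direction of this change.

With nothing to point one way or the other, compound 4 is expected to stay close to compound 2, with a step of a number 6.1 percentage points higher from compound 2 to compound 4 (within the scatter) that may fall either way. The estimate for compound 4 in this assay is 50%, with a range from 33% to 68%.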

Compound 4, a percentage reported as activity, at one concentration (the size of the read-out at that concentration, not a potency): 64.2%
Beside the measured number, compound 4's estimate is 14.2 percentage points below it; low and high end bracket the measured number.
By their numbers in this assay, from the lowest: compound 2; then compounds 1, 3 and 4 (each within the scatter of the next).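

In this assay, for the compounds shown here, the step of a number 20.3 percentage points higher from compound 2 to compound 4 (beyond the scatter) shows that the cyano group counts for this read-out, at a place that no earlier step had touched: with hydrogen on that aromatic carbon, the effect at the one concentration tested is weaker, and the change lies beyond the scatter. This step has the same printed size as a number 20.3 percentage points higher from compound 2 to compound 3 (beyond the scatter), so going from 4-cyanophenyl to phenyl weighs as much here as phenyl in place of methyl on an aromatic nitrogen, and compound 2 now stands apart as the strongest of the four, while compounds 1, 3 and 4 lie each within the scatter of the next. Nothing measured here accounts for why this change acts as it does.

Going by these compounds, whether a carboxylic acid, an amine or a methoxy group at this place would keep the number of compound 2 or lose it as hydrogen does remains open. Also open, on these data alone, is whether going from 4-cyanophenyl to phenyl would weigh the same with 4-methyl-4H-1,2,4-triazol-3-yl or 1-phenyl-1H-tetrazol-5-yl on the sulfur.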